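The source may hold more compounds than are shown below. What is called first, only, known or untested is meant among the compounds shown, and "the series" means these compounds.

Compound 1, `N=C(Nc1cccc2ccccc12)Nc1cccc2ccccc12`, in an assay on membranes from brain (Cavia porcellus) for binding affinity to Sigma non-opioid intracellular receptor 1 (Homo sapiens), read by radioligand binding; a higher number here means a weaker inhibitor, a lower number a stronger inhibitor: 165 nM
Compound 2, `CN(C(=N)Nc1cccc2ccccc12)c1cccc2ccccc12`, in this assay: 4800 nM
Compound 3, `Cc1cccc(NC(=N)Nc2cccc3ccccc23)c1`, in this assay: 75 nM

Compound 2 differs from compound 1 by a single change, (methyl in place of hydrogen on a nitrogen on an aromatic ring), and that change brought a 29-fold higher number from compound 1 to compound 2 (1.46 log units; beyond the scatter). Compound 3 is built on a different core; the difference between the two cores is not broken down here. Among the three measured compounds, compound 3 has the lowest number in this assay.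

Compound 4, `Cc1cccc(N(C)C(=N)Nc2cccc3ccccc23)c1`, has not yet been measured. It differs from compound 3 by methyl in place of hydrogen on a nitrogen on an aromatic ring, which is the same change as from compound 1 to compound 2, with the same surroundings at the place of change. If this change acts on the core of compound 3 as it did on the core of compound 1, a step of similar size is expected, a 27-fold higher number from compound 3 to compound 4 (1.43 log units; beyond the scatter), because of a 29-fold higher number from compound 1 to compound 2 (1.46 log units; beyond the scatter). Compound 4 is therefore estimated at 2000 nM, most likely between 500 nM and 8000 nM. Among the measured compounds shown here, only one earlier example of this change is available, so the estimate carries real uncertainty.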

Compound 4, half-maximal inhibitory concentration: 1860 nM
Compound 4: the middle estimate sits 1.1-fold (0.03 log units) above what was measured, within the range that was stated.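

Putting methyl in place of hydrogen on the nitrogen of compound 3 gave, in this assay, a 25-fold higher number from compound 3 to compound 4 (1.39 log units; beyond the scatter). The change therefore carried over from the core of compound 1 to the core of compound 3 at much the same size, and the two steps cannot be told apart: the same change on two cores in this assay, a 29-fold higher number (1.46 log units; beyond the scatter) from compound 1 to compound 2 and a 25-fold higher number (1.39 log units; beyond the scatter) from compound 3 to compound 4, 1.2-fold (0.07 log units) apart, within the scatter of two such steps

Among the compounds shown here, this agreement rests on only two cores, with the same surroundings at the place of change, so it shows that the step repeated here, but not why the number rises so far or that any other core would respond in the same way.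

The compounds shown leave open whether ethyl, a longer chain or a benzyl group on that same nitrogen would bring a step like the one seen with methyl. They also leave open whether the step would keep its size on a core carrying a hydroxyl group or an amine.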